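Working notes: phenylsulfonyl in place of phenoxy

The source may hold more compounds than are shown below. What is called first, only, known or untested is meant among the compounds shown, and "the series" means these compounds.

Measured so far in a functional assay (aorta) with Oryctolagus cuniculus as the target; on this read-out higher numbers stand for weaker binding and lower numbers for tighter binding:
compound 1 `COc1cc(C(C)=O)ccc1OCCCN1CCC(C(c2ccc(F)cc2)c2ccc(F)cc2)CC1` gives 1.59 nM
compound 2 `Fc1ccc(C(c2ccc(F)cc2)C2CCN(CCCOc3ccc4ccccc4c3)CC2)cc1` gives 7.94 nM
compound 3 `Fc1ccc(C(c2ccc(F)cc2)C2CCN(CCCOc3ccccc3)CC2)cc1` gives 1.59 nM

Compound 1 shares the lowest number of the three with compound 3 at 1.59 nM, and only compound 2 sits apart from them, at 7.94 nM.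

The next compound, compound 4 `O=S(=O)(CCCN1CCC(C(c2ccc(F)cc2)c2ccc(F)cc2)CC1)c1ccccc1`, has phenylsulfonyl in place of phenoxy on a saturated chain carbon, three bonds along the chain from an amine nitrogen in a ring.

The measured steps change only the group on the oxygen. They are no change at the digits printed from compound 1 to compound 3 (within the scatter), a 5.0-fold lower number from compound 2 to compound 3 (0.70 log units; beyond the scatter) and a 5.0-fold higher number from compound 1 to compound 2 (0.70 log units; beyond the scatter). None of them replaces phenoxy with phenylsulfonyl, so they bear on this change only indirectly. They suggest a size, modest at most, but give no direction. A modest rise in this assay is tentatively expected, with no change beyond the scatter also possible. The estimate means a 2.5-fold higher number from compound 3 to compound 4 (0.40 log units; beyond the scatter) as the expected step. Compound 4 is estimated at 4 nM, with an expected range from 1 nM to 16 nM.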

Compound 4, dissociation constant: 20 nM
The estimate for compound 4 lay 5.0-fold (0.70 log units) below the measured number; measured number outside the range, above it.
By their numbers in this assay, from the lowest: compounds 1 and 3 (each within the scatter of the next); then compound 2; then compound 4.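

Swapping phenoxy for phenylsulfonyl, with the phenyl ring kept, gives a 13-fold higher number from compound 3 to compound 4 (1.10 log units; beyond the scatter) in this assay and is the first large step at this place on the chain. Set against 4-acetyl-2-methoxyphenoxy, the same place gives a 13-fold higher number from compound 1 to compound 4 (1.10 log units; beyond the scatter) and, like the step above, this is larger than any step among the groups on the oxygen. Even from the highest number among the earlier compounds there is a 2.5-fold higher number from compound 2 to compound 4 (0.40 log units; beyond the scatter) of modest size, so the change of the link itself moves the read-out, not only the group carried on it.

Going by these compounds, whether a thioether, an amide or a plain methylene link at this place would stay level with compound 3 remains open, as does the effect of a longer chain. Nothing at hand accounts for the rise.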